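The source may hold more compounds than are shown below. What is called first, only, known or untested is meant among the compounds shown, and "the series" means these compounds.

Working notes on the series in a functional assay on SW-620 cells (Homo sapiens) for cytotoxicity, read by sulforhodamine B assay, with a stated time of 48 h; on this read-out lower numbers stand for stronger inhibition and higher numbers for weaker inhibition.

Of the compounds shown here, three sharing one core have been measured. Compound 1 `COc1ccc(C2=NO[C@]3(C2)C(=O)O[C@@H]2[C@H]3CC[C@H](C)[C@]3(O)C=CC(=O)[C@@]23C)cc1` gives 41000 nM in this assay. Compound 2 `C[C@H]1CC[C@@H]2[C@@H](OC(=O)[C@]23CC(c2ccccc2)=NO3)[C@]2(C)C(=O)C=C[C@@]12O` gives 45400 nM. Compound 3 `C[C@H]1CC[C@@H]2[C@@H](OC(=O)[C@]23CC(c2ccc(O)cc2)=NO3)[C@]2(C)C(=O)C=C[C@@]12O` gives 89000 nM, the highest of the three numbers: the step of a 2.0-fold higher number from compound 2 to compound 3 (0.29 log units; within the scatter) is within the scatter, while the step of a 2.2-fold higher number from compound 1 to compound 3 (0.34 log units; beyond the scatter) is beyond it, though modest. The step of a 1.1-fold higher number from compound 1 to compound 2 (0.04 log units; within the scatter) is within the scatter.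

Compound 4 `C[C@H]1CC[C@@H]2[C@@H](OC(=O)[C@]23CC(c2ccccc2Cl)=NO3)[C@]2(C)C(=O)C=C[C@@]12O` has not yet been measured. Relative to compound 3 the change is 2-chlorophenyl in place of 4-hydroxyphenyl on a carbon with a double bond to nitrogen. Among the measured compounds shown here, two measured steps bear on this. The step of a 2.0-fold higher number from compound 2 to compound 3 (0.29 log units; within the scatter) shows what the hydroxy adds; its removal in compound 4 should undo roughly that much. The step of a 1.1-fold higher number from compound 1 to compound 2 (0.04 log units; within the scatter) shows that the bare phenyl and the methoxyphenyl give numbers within the scatter of each other. As far as these compounds go, nothing measured covers the chlorine, so its contribution is unknown. The expectation is therefore a number near that of compound 2, with the step of a 2.0-fold lower number from compound 3 to compound 4 (0.30 log units; within the scatter) from compound 3 to compound 4 expected to be small and within the scatter. Compound 4 is estimated at 45000 nM in this assay, in the range 18000 nM to 110000 nM.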

Compound 4, half-maximal inhibitory concentration: 9000 nM
Beside the measured number, compound 4's estimate is 5.0-fold (0.70 log units) above it; measured number below the stated range.
By their numbers in this assay, from the lowest: compound 4; then compounds 1, 2 and 3 (each within the scatter of the next, the first and the last beyond it).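

In this assay, among the compounds shown here, the aryl group on the carbon with a double bond to nitrogen can move the number well beyond the scatter, which the hydroxy and methoxy variations on the phenyl ring did not do: the earlier steps stayed within the scatter or only just beyond it, while chloro in place of hydrogen gives a 5.0-fold lower number from compound 2 to compound 4 (0.70 log units; beyond the scatter). The 2-chlorophenyl group also gives a 4.6-fold lower number from compound 1 to compound 4 (0.66 log units; beyond the scatter) and a 9.9-fold lower number from compound 3 to compound 4 (1.00 log units; beyond the scatter), so compound 4 is the most potent of the four in this assay, with its steps to all three others printed as beyond the scatter. Nothing measured here accounts for this change in the number.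

The compounds shown carry chlorine in a single placement, so it remains open whether the lower number belongs to the chloro group itself or to where it sits on the phenyl ring, and whether bromo, trifluoromethyl or nitrile in the same place would do the same. Also open, as far as these compounds go, is how an amine or a carboxylic acid on that ring would read in this assay, and whether the effect of chloro holds with any change to the shared core.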